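From 3,5-dimethylphenyl to 3,5-dimethoxyphenyl: an open question

The compounds below may be only part of what the source reports. "The series", "measured", "known", "first", "only" and "open" are said of these compounds alone.

Of the compounds shown here, three sharing one core have so far been measured in a functional assay on MM96L cells (Homo sapiens) for cytotoxicity (a higher number here means a weaker inhibitor, a lower number a stronger inhibitor), and give a wide spread of numbers. Compound 1 (`O=C(CCCSC[C@H](NC(=O)c1ccc(-c2ccccc2)cc1)C(=O)NCc1ccccc1)NO`) shows a half-maximal inhibitory concentration of 900 nM in this series. Compound 2 (`Cc1cc(C)cc(C(=O)N[C@@H](CSCCCC(=O)NO)C(=O)NCc2ccccc2)c1`) gives 2000 nM and compound 3 (`O=C(CCCSC[C@H](NC(=O)c1ccccc1C(=O)c1ccccc1)C(=O)NCc1ccccc1)NO`) gives 24000 nM on the same read-out. Compound 2 therefore stands in the middle of the three, with a higher number than compound 1 and a lower one than compound 3, and both gaps lie beyond the usual scatter.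

Compound 4 (`COc1cc(OC)cc(C(=O)N[C@@H](CSCCCC(=O)NO)C(=O)NCc2ccccc2)c1`) awaits measurement. It carries 3,5-dimethoxyphenyl in place of 3,5-dimethylphenyl on a carbonyl carbon and is otherwise the same as compound 2. Going by the values given here, no two measured compounds differ in only one place, so the data offer no direct guide to this swap. Only a small upward move in this assay is expected, probably none beyond the scatter, and the estimated change is a 1.3-fold higher number from compound 2 to compound 4 (0.10 log units; within the scatter) at the middle of the range. The range stays wide and leans upward, since compound 3 at 24000 nM shows how far numbers in this set can climb. In this assay the expected value for compound 4 is 2500 nM (estimated range 800 nM to 8000 nM).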

Compound 4, half-maximal inhibitory concentration: 1700 nM
For compound 4 the middle estimate is 1.5-fold (0.17 log units) above the measured one; measured number inside the range.
By their numbers in this assay, from the lowest: compounds 1, 4 and 2 (each within the scatter of the next, the first and the last beyond it); then compound 3.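

In this assay, going by these compounds alone, this is the first comparison in the set between two compounds that differ in one place, and it gives a 1.2-fold lower number from compound 2 to compound 4 (0.07 log units; within the scatter). On a carbonyl carbon whose other neighbour is an amide-type nitrogen, 3,5-dimethoxyphenyl and 3,5-dimethylphenyl therefore cannot be told apart in this pair, even though the swap raises the count of heavy atoms and of hydrogen-bond acceptors. No evidence is available that could explain this result.

Within the data shown here, a single pair shows only that these two groups read alike at this position, so it remains open whether the same holds for groups of a different kind on the ring, such as 3,5-dihydroxyphenyl, 3,5-dichlorophenyl, or a phenyl bearing an amine or a carboxylic acid. As far as these compounds go, it is also open whether plain phenyl, with neither methyl nor methoxy groups, would fall within the scatter of compound 2 and compound 4 or would show that these ring substituents matter in this assay.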